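Vero cytotoxicity of benzyloxy-substituted core: naphthyl replacement

The source may report more compounds than this note shows. Statements on the series, on what has been measured and on what is new or still open speak of the compounds shown alone.

Measured so far:
compound 1 `Cc1cccc(COc2ccc3c(c2)[C@@H](O)CN(C)C3)c1`, > 50000 nM
compound 2 `CN1Cc2ccc(OCc3ccc(Oc4ccccc4)cc3)cc2[C@@H](O)C1`, 3400 nM
compound 3 `CN1Cc2ccc(OCc3ccc(-c4ccc(-c5ccccc5)cc4)cc3)cc2[C@@H](O)C1`, 280 nM

In an ADME assay on Vero cells (Chlorocebus sabaeus) for cytotoxicity, read by sulforhodamine B assay, with a stated time of 72 h (a lower number here means a stronger inhibitor, a higher number a weaker inhibitor), compound 1 gives only the limit > 50000 nM and no number, the limit (the limit of > 50000 nM in this assay, at which 1 of the 3 values shown sits). Compound 2 stands at the higher of the two actual numbers, with 3400 nM in this assay; compound 3, at 280 nM, sits lower by a gap beyond the scatter. Across these three the number falls as the terminal aromatic group grows, with none of the three going against that.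

Compound 4 `CN1Cc2ccc(OCc3ccc(-c4ccc5ccccc5c4)cc3)cc2[C@@H](O)C1` is not yet measured. It differs from compound 2 by naphthalen-2-yl in place of phenoxy on an aromatic carbon. The step from compound 2 to compound 4 is expected to lower the number beyond the scatter, by a 3.8-fold lower number from compound 2 to compound 4 (0.58 log units; beyond the scatter), because compound 3 gives 280 nM with a still larger aromatic extension. The estimate for compound 4 in this assay is 900 nM, with a range from 250 nM to 3500 nM.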

Compound 4, half-maximal inhibitory concentration: 310 nM
For compound 4 the middle estimate is 2.9-fold (0.46 log units) above the measured one; the range from low to high includes it.
By their numbers in this assay, from the lowest: compounds 3 and 4 (each within the scatter of the next); then compound 2. At a limit, above all of these: compound 1.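

In this assay, among the compounds shown here, this is the first step that can be read at this aromatic carbon, para to a large group, and it is large: an 11-fold lower number from compound 2 to compound 4 (1.04 log units; beyond the scatter), with naphthalen-2-yl in place of phenoxy. The change removes the phenoxy oxygen and adds a second aromatic ring at once, so this single step cannot separate the two. Compound 3 gives 280 nM and compound 4 gives 310 nM, values within the scatter of each other, so two different terminal groups now share this range.

No measured property here accounts for the step. Open, going by these compounds, is whether a plain phenyl on the same carbon would separate the oxygen from the added ring, and how an amine or a carboxylic acid on the terminal group would read in this assay.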